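Urea series on a shared lactone core: moving the methyl

This account rests on a few compounds, and the source may have more. Where it says the series, first, only, none or still open, it means among the compounds named here.

Measured so far:
compound 1 `O=C(/C=C/c1ccccc1)Nc1ccc2c(c1)COC2=O`, 7240 nM
compound 2 `Cc1ccccc1NC(=O)Nc1ccc2c(c1)COC2=O`, 900 nM

In a functional assay on cells (T-cell, Mus musculus) for inhibition (on this read-out lower numbers stand for stronger inhibition and higher numbers for weaker inhibition), compound 1 gives 7240 nM, the cinnamide. Compound 2, the urea, gives 900 nM in this assay, the lower of the two numbers, and its gap to compound 1 is beyond the scatter. Which part of the urea drives that gap cannot be read from two compounds.

Compound 3 `Cc1ccc(NC(=O)Nc2ccc3c(c2)COC3=O)cc1` keeps the urea and the core and changes only the aryl group: 4-methylphenyl in place of 2-methylphenyl on an amide-type nitrogen. Within the data shown here, no measured pair here shows this kind of change, so there is no step to lean on. The expectation is a step from compound 2 to compound 3 of a 1.3-fold higher number from compound 2 to compound 3 (0.12 log units; within the scatter), that is, no shift beyond the scatter in either direction. Compound 3 is therefore estimated at 1200 nM in this assay, with a range from 400 nM to 4000 nM.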

Compound 3, half-maximal inhibitory concentration: 2670 nM
Estimate against measurement, compound 3: 2.2-fold (0.35 log units) below; measured number inside the range.
By their numbers in this assay, from the lowest: compound 2; then compound 3; then compound 1.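

In this assay, 4-methylphenyl in place of 2-methylphenyl on an amide-type nitrogen gives a 3.0-fold higher number from compound 2 to compound 3 (0.47 log units; beyond the scatter). With the urea, the core and the atom count all unchanged, the aryl group is shown to matter to this read-out through where its methyl stands, which the earlier compounds could not show, as they offered no pair differing in one place. No measurement shown here bears on the reason for this step.

From the compounds shown here alone, without plain phenyl as a reference, it remains open whether 2-methylphenyl improves on the unsubstituted ring, 4-methylphenyl falls short of it, or both. Also open, going by these compounds, is how the number responds when an ethyl group, a chlorine atom or a carboxylic acid takes the place of the methyl on this ring.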